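The source may report more compounds than this note shows. Statements on the series, on what has been measured and on what is new or still open speak of the compounds shown alone.

Compounds measured so far:
- compound 1, `CCOC(=O)NC(=O)NC1=CS(=O)(=O)O[C@@]12[C@@H](CO[Si](C)(C)C(C)(C)C)O[C@@H](n1cc(C)c(=O)n(C)c1=O)[C@@H]2O[Si](C)(C)C(C)(C)C`: 14000 nM
- compound 2, `Cc1cn([C@@H]2O[C@H](CO[Si](C)(C)C(C)(C)C)[C@@]3(OS(=O)(=O)C=C3NCC(=O)OCc3ccccc3)[C@H]2O[Si](C)(C)C(C)(C)C)c(=O)n(C)c1=O`: > 200000 nM
- compound 3, `CCNC(=O)NC1=CS(=O)(=O)O[C@@]12[C@@H](CO[Si](C)(C)C(C)(C)C)O[C@@H](n1cc(C)c(=O)n(C)c1=O)[C@@H]2O[Si](C)(C)C(C)(C)C`: 10000 nM

In a functional assay on HEL cells (Homo sapiens) (on this read-out higher numbers stand for lower toxicity in this test and lower numbers for higher toxicity in this test), compound 1 gives 14000 nM. Compound 3 gives 10000 nM in this assay, and the two numbers lie within the scatter of each other, so no order between compound 1 and compound 3 is claimed. Compound 2 gives > 200000 nM in this assay, which is a limit of the assay and not a number. Of the two numbers shown, compound 1 is the higher one, with compound 3 nearest, a 1.4-fold lower number from compound 1 to compound 3 (0.15 log units; within the scatter).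

The compound not yet measured is compound 4, `Cc1cn([C@@H]2O[C@H](CO[Si](C)(C)C(C)(C)C)[C@@]3(OS(=O)(=O)C=C3NCCC(N)=O)[C@H]2O[Si](C)(C)C(C)(C)C)c(=O)n(C)c1=O`. It differs from compound 1 in one place: 2-carbamoylethyl in place of (ethoxycarbonyl)carbamoyl on an amine nitrogen.

Among the compounds with values here, two measured steps bear on this change. The step of an at least 14-fold higher number from compound 1 to compound 2 (1.15 log units; beyond the scatter) removed the same (ethoxycarbonyl)carbamoyl group and put an alkyl chain on the amine nitrogen, and it went to the limit described at the limit of > 200000 nM in this assay, at which 1 of the 3 values shown sits. The step of an at least 20-fold lower number from compound 2 to compound 3 (1.30 log units; beyond the scatter) ran the other way, back to a carbamoyl-type group. By contrast, a 1.4-fold lower number from compound 1 to compound 3 (0.15 log units; within the scatter) kept the carbamoyl and stayed within the scatter. The change to compound 4 resembles the move toward compound 2, so a step upward beyond the scatter is expected, a 6.4-fold higher number from compound 1 to compound 4 (0.81 log units; beyond the scatter), with a fair chance that this assay again reports only a limit. Compound 4 is therefore estimated at 90000 nM, within 25000 nM to 250000 nM.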

Compound 4, half-maximal cytotoxic concentration: 14800 nM
Compound 4: middle estimate off by 6.1-fold (0.78 log units), on the high side, outside the stated range (below it).
By their numbers in this assay, from the lowest: compounds 3, 1 and 4 (each within the scatter of the next). At a limit, above all of these: compound 2.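

In this assay, 2-carbamoylethyl in place of (ethoxycarbonyl)carbamoyl on the amine nitrogen gives a 1.1-fold higher number from compound 1 to compound 4 (0.02 log units; within the scatter), and the same group in place of ethylcarbamoyl gives a 1.5-fold higher number from compound 3 to compound 4 (0.17 log units; within the scatter), so a chain attached at this nitrogen can give a number that lies within the scatter of both carbamoyl-type compounds. The large step seen earlier therefore does not follow from the loss of the carbamoyl-type group alone, and the end of the chain now comes into view: an at least 13-fold lower number from compound 2 to compound 4 (1.13 log units; beyond the scatter), with carbamoylmethyl in place of benzyloxycarbonyl on a saturated chain carbon bound to an amine nitrogen. Compound 2 still stands at a limit of the assay and not at a number: the limit of > 200000 nM in this assay, at which 1 of the 4 values shown sits.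

The compounds shown leave open whether the benzyl group or the ester in the chain of compound 2 goes with the large step, a question that a chain ending in a carboxylic acid or an ethyl ester would help to separate. They also leave open how far the chain can be changed at this nitrogen, for instance to a longer chain or one ending in an amine.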